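Hydroxy in Place of Ureido: What Compound 4 Should Show

The source may hold more compounds than are shown below. What is called first, only, known or untested is meant among the compounds shown, and "the series" means these compounds.

Three compounds were measured in a functional assay on MCF7 cells (Homo sapiens) for inhibition, read by sulforhodamine B assay, with a stated time of 48 h, tested at 50 uM; a higher number here means more inhibition of growth at the concentration tested, a lower number less inhibition of growth:
Compound 1, `COc1cc2c(cc1CC=C(C)C)/C(=N/NC(N)=O)C[C@@H](c1ccc(O)cc1)O2`, gave 93%.
Compound 2, `COc1ccc([C@@H]2C/C(=N/OCc3cn(-c4ccccc4CO)nn3)c3cc(CC=C(C)C)c(OC)cc3O2)cc1`, gave 100%.
Compound 3, `COc1cc2c(cc1CC=C(C)C)C(=O)C[C@@H](c1ccc(Oc3cccc([N+](=O)[O-])c3)cc1)O2`, gave 53%.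

Among these three numbers compound 1 stands second highest. Its nearest neighbour is compound 2, whose value lies within the scatter of that of compound 1, so the two cannot be ordered. Compound 3 lies furthest away, beyond the scatter and lower, and it is the only one of the three without a substituent on the double-bonded carbon of the shared core.

Compound 4, `COc1cc2c(cc1CC=C(C)C)/C(=N/O)C[C@@H](c1ccc(O)cc1)O2`, differs from compound 1 in a single place: hydroxy in place of ureido on a double-bonded nitrogen. Both groups keep a hydrogen-bond donor and acceptor at that nitrogen, and the rest of the molecule is unchanged. Within the data shown here, no step between measured compounds matches this change, so the expectation rests on compound 1 alone, whose value in this assay is 93%. The step of a number 8 percentage points lower from compound 1 to compound 4 (within the scatter) is expected to be small, downward if anything, and not clearly beyond the scatter. Compound 4 is therefore estimated at 85%, within 65% to 100%.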

Compound 4, percent growth inhibition at one concentration: 93%
For compound 4 the middle estimate is 8 percentage points below the measured one; measured number inside the range.
By their numbers in this assay, from the lowest: compound 3; then compounds 1, 4 and 2 (each within the scatter of the next).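

In this assay, hydroxy in place of ureido on a double-bonded nitrogen gives no change at the digits printed from compound 1 to compound 4 (within the scatter), the only step at this position among the compounds shown. At this single tested concentration, the whole ureido group can therefore give way to a lone hydroxy with no visible loss of growth inhibition, something that compound 1 alone could not show. Nothing shown explains why the two groups give such similar numbers.

Because compound 1 and compound 4 both stand high on this read-out, a single concentration leaves open whether the two would still match at lower concentrations. Going by these compounds, it also remains open whether a methoxy, an amine or a longer chain carrying a carboxylic acid on the same nitrogen would keep the growth inhibition seen with hydroxy and ureido.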